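The compounds below may be only part of what the source reports. "The series", "measured", "known", "first", "only" and "open" are said of these compounds alone.

The measured compounds:
Compound 1, `COc1ccc(C(CC(=O)O)CC(=O)NNC(=O)c2cccc(NC(=N)N)c2)cc1`, gives 1.
Compound 2, `N=C(N)Nc1cccc(C(=O)NNC(=O)CC(CC(=O)O)c2cc(Cl)cc(Cl)c2)c1`, gives 2.24.
Compound 3, `COc1ccc(C(CC(=O)O)CC(=O)NNC(=O)CCCCNc2ccccn2)cc1`, gives 1.94.

All three numbers come from a physicochemical assay for lipophilicity; on this read-out higher numbers stand for higher lipophilicity and lower numbers for lower lipophilicity. Compound 1 and compound 2 differ in a single place: 3,5-dichlorophenyl in place of 4-methoxyphenyl on a saturated chain carbon bound to two saturated chain carbons. That change produced a number 1.24 log units higher from compound 1 to compound 2 (beyond the scatter). Compound 3 is built on another core, and the difference between the two cores is not broken down here. Compound 4, `O=C(O)CC(CC(=O)NNC(=O)CCCCNc1ccccn1)c1cc(Cl)cc(Cl)c1`, has not yet been measured in this assay. It differs from compound 3 in one place: 3,5-dichlorophenyl in place of 4-methoxyphenyl on a saturated chain carbon bound to two saturated chain carbons. The two places are described in the same words, so this is the same change that was made between compound 1 and compound 2. A step of similar size is expected here because a number 1.24 log units higher from compound 1 to compound 2 (beyond the scatter) was seen for that one earlier case, which is all the evidence there is. Compound 4 is therefore expected to show a number 1.24 log units higher from compound 3 to compound 4 (beyond the scatter). For compound 4 the estimate is 3.18, most likely between 2.7 and 3.65.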

Compound 4, partition coefficient: 3.19
Compound 4: middle estimate off by 0.01 log units, on the low side; the measured number falls inside the stated range.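

In this assay, putting 3,5-dichlorophenyl in place of 4-methoxyphenyl gave a number 1.25 log units higher from compound 3 to compound 4 (beyond the scatter), and the same change on the core of compound 1 gave a number 1.24 log units higher from compound 1 to compound 2 (beyond the scatter), so the step kept nearly the same size on both cores. Going by these compounds alone, this shows that the change carried over from one core to the other, but with only one pair of compounds per core, it does not show that the step would hold on every core. Nothing shown here explains why the two steps came out so alike.

The compounds shown leave open whether the step would keep its size on a core with an amine in place of the carboxylic acid. They also leave open what a longer chain on the far side of the core would do to it.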